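The compounds below may be only part of what the source reports. "The series", "measured", "known", "first", "only" and "open" are said of these compounds alone.

Among the compounds with values here, in an in vitro assay on cells for inhibition of Amine oxidase [flavin-containing] B (Homo sapiens), read by Amplex Red, with a stated time of 15 min (a lower number here means a stronger inhibitor, a higher number a weaker inhibitor), compound 3 `O=C(/C=C/C=C/c1ccccc1)c1ccccc1O` gives 106 nM, the second highest of the three numbers measured so far. Its nearest neighbour is compound 2 `O=C(/C=C/C=C/c1ccccc1)c1cc(Cl)ccc1O`, which in this assay gives 54.8 nM; the step of a 1.9-fold higher number from compound 2 to compound 3 (0.29 log units; within the scatter) lies within the scatter, so the two cannot be told apart. Its furthest neighbour is compound 1 `O=C(/C=C(O)/C=C/c1ccc([N+](=O)[O-])cc1)c1ccccc1O`, which gives 2670 nM and is thus a clearly weaker inhibitor.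

Compound 4 `O=C(/C=C/C=C/c1ccc([N+](=O)[O-])cc1)c1ccccc1O` has not yet been measured. The change from compound 3 is nitro in place of hydrogen on an aromatic carbon. Within the data shown here, no measured step bears directly on this change. Compound 1 also carries a nitro group, but it differs from compound 4 in more than one place, since its chain additionally carries a hydroxyl group, so its value shows only that this combination is weak. Among the measured compounds shown here, the one measured step concerns the other ring and was within the scatter. The expectation is therefore uncertain; a weaker inhibitor is expected, with a step of a 3.8-fold higher number from compound 3 to compound 4 (0.58 log units; beyond the scatter). Compound 4 is estimated at 400 nM, with a range from 100 nM to 2000 nM.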

Compound 4, half-maximal inhibitory concentration: 160 nM
Compound 4: middle estimate off by 2.5-fold (0.40 log units), on the high side, within the range that was stated.
By their numbers in this assay, from the lowest: compounds 2, 3 and 4 (each within the scatter of the next, the first and the last beyond it); then compound 1.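

Placing a nitro group on the aromatic carbon para to a large group gives a 1.5-fold higher number from compound 3 to compound 4 (0.18 log units; within the scatter), so compound 3 and compound 4 cannot be told apart, and this position accepts a group of three heavy atoms without a clear loss of inhibition. The nitro group therefore does not go with the weak number of compound 1; the large difference goes with the chain instead, where hydrogen in place of hydroxy gives a 17-fold lower number from compound 1 to compound 4 (1.22 log units; beyond the scatter). Nothing available explains either result in terms of a measured property.

On these data alone, what an amine or a carboxylic acid would do on the same aromatic carbon remains open. As far as these compounds go, it is also open whether a methoxy group on that chain carbon would go with a step as large as the one seen for hydroxy.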